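A few compounds are considered here, and "the series" means these few. Any claim that something is new, unique, unknown or untested is made for them only; others in the source may bear on it.

Measured so far:
compound 1, `CCOC(=O)Cn1cc(CNC(=O)c2cnc(Nc3ccc(C#N)cc3)cc2Oc2c(C)cc(C)cc2C)nn1`, in an ADME assay on MT4 cells (Homo sapiens) for cytotoxicity, read by MTT assay, with a stated time of 5 days (on this read-out lower numbers stand for higher toxicity in this test and higher numbers for lower toxicity in this test), gives 9530 nM.
compound 2, `Cc1cc(C)c(Oc2cc(Nc3ccc(C#N)cc3)ncc2C(=O)NCc2cn(Cc3ccc(Cl)cc3)nn2)c(C)c1`, in this assay gives >= 120000 nM, which is a limit of the assay and not a number.

Compound 1 therefore holds the only number shown in this assay; the other value is a limit (the limit of >= 120000 nM in this assay, at which 1 of the 2 values shown sits). Compound 3, `Cc1cc(C)c(Oc2cc(Nc3ccc(C#N)cc3)ncc2C(=O)NCc2cn(Cc3cccc([N+](=O)[O-])c3)nn2)c(C)c1`, is not yet measured. It differs from compound 1 by 3-nitrophenyl in place of ethoxycarbonyl on a saturated chain carbon bound to an aromatic nitrogen. Among the compounds with values here, the one measured step that bears on this is an at least 12-fold higher number from compound 1 to compound 2 (1.10 log units; beyond the scatter), where another aromatic ring also took the place of ethoxycarbonyl on a saturated chain carbon bound to an aromatic nitrogen. As far as these compounds go, since compound 2 only reached the limit (the limit of >= 120000 nM in this assay, at which 1 of the 2 values shown sits), the full size of that step is unknown. A step of similar direction is expected for compound 3, namely a 6.3-fold higher number from compound 1 to compound 3 (0.80 log units; beyond the scatter). Compound 3 is accordingly estimated at 60000 nM, with a range from 15000 nM to 200000 nM, and a limit is quite possible.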

Compound 3, half-maximal cytotoxic concentration: >= 156000 nM
Compound 3 was reported as a limit; the forecaster's own chance of this, stated with the estimate: 50%; at least 2.6-fold (0.41 log units) between middle value and limit.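

In this assay, a second aromatic ring at this position moves the number the same way as the first: an at least 16-fold higher number from compound 1 to compound 3 (1.21 log units; beyond the scatter). With 4-chlorophenyl in compound 2 and 3-nitrophenyl in compound 3, both replacements of ethoxycarbonyl on a saturated chain carbon bound to an aromatic nitrogen now end at a limit of the assay rather than a number, so the earlier rise is not confined to one substituted ring. The values of compound 2 and compound 3 are both limits, so the step between them cannot be read and the two rings cannot be ranked.

As far as these compounds go, how high the true number lies for either ring remains open. Also open, from the compounds shown here alone, is whether a carboxylic acid or a longer carbon chain in place of ethoxycarbonyl would shift the number in the same direction, or whether this rise requires an aromatic ring.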